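Swapping 4-Chlorophenyl for Benzyl in Antiproliferative Compounds

This account rests on a few compounds, and the source may have more. Where it says the series, first, only, none or still open, it means among the compounds named here.

Compound 3 `O=c1nc2oc(CCCCl)c(C#CCCCCl)c2cn1Cc1cn(-c2ccc(Cl)cc2)nn1` and compound 1 `O=c1nc2oc(CCCCl)c(C#CCCCCl)c2cn1Cc1cn(Cc2ccccc2)nn1` share one core and differ only in one place: benzyl in place of 4-chlorophenyl on an aromatic nitrogen. In a functional assay on CFPAC-1 cells (Homo sapiens) for antiproliferative activity, read by MTT assay, with a stated time of 72 h (a lower number here means a stronger inhibitor, a higher number a weaker inhibitor), compound 3 reaches only a limit of the assay, > 100000 nM. Compound 1, in this assay, gives 32800 nM. The step of an at least 3.0-fold lower number from compound 3 to compound 1 (0.48 log units; beyond the scatter) is bounded rather than fixed, because the limit of > 100000 nM in this assay, at which 2 of the 3 values shown sit, is where the starting point sits.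

Compound 2 `O=c1nc2oc(C3CC3)cc2cn1Cc1cn(-c2ccc(Cl)cc2)nn1` carries a different core; the difference between the two cores is not broken down here. In this assay compound 2 also sits at a limit, > 100000 nM. Compound 4 `O=c1nc2oc(C3CC3)cc2cn1Cc1cn(Cc2ccccc2)nn1` has not been measured and differs from compound 2 by benzyl in place of 4-chlorophenyl on an aromatic nitrogen, the same change as that between compound 3 and compound 1, at the same place.

The expectation for compound 4 rests only on the earlier step of an at least 3.0-fold lower number from compound 3 to compound 1 (0.48 log units; beyond the scatter), and on the value of compound 2 being a limit, so the step of an at least 1.6-fold lower number from compound 2 to compound 4 (0.22 log units; that floor lies within the scatter) in this assay is estimated rather than derived. Compound 4 is expected to give about 60000 nM in this assay, within a range from 15000 nM to 200000 nM, and a limit rather than a number remains possible.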

Compound 4, half-maximal inhibitory concentration: 48500 nM
Compound 4: the middle estimate sits 1.2-fold (0.09 log units) above what was measured; the range from low to high includes it.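

In this assay, benzyl in place of 4-chlorophenyl on an aromatic nitrogen gives an at least 2.0-fold lower number from compound 2 to compound 4 (0.31 log units; beyond the scatter) on the core of compound 2 and so points the same way as on the core of compound 3. This shows that the change carries over in direction between the two cores shown, but it does not show that it carries over in size: the same change on two cores in this assay, an at least 3.0-fold lower number (0.48 log units; beyond the scatter) from compound 3 to compound 1 and an at least 2.0-fold lower number (0.31 log units; beyond the scatter) from compound 2 to compound 4; the limit leaves it open whether they differ. Neither step has a fixed size, and each gives only a floor, since each starts from a limit rather than a number: the limit of > 100000 nM in this assay, at which 2 of the 4 values shown sit.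

The compounds shown leave open whether a plain phenyl, a chlorobenzyl or a longer phenylethyl chain on that aromatic nitrogen would lower the number further, which would separate the loss of chlorine from the gain of the extra carbon. They also leave open whether the same change holds on a third core, for instance one carrying an amine or a carboxylic acid.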